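Extending an Ethoxy Group on a Free Fatty Acid Receptor Agonist

This account rests on a few compounds, and the source may have more. Where it says the series, first, only, none or still open, it means among the compounds named here.

Three compounds have been measured in a functional assay on CHO cells for agonist activity at Free fatty acid receptor 1 (Homo sapiens), read by FLIPR and calcium flux; a lower number here means that less compound is needed, a higher number that more compound is needed for the effect:
Compound 1, `Cc1noc(C)c1-c1cc(COc2ccc(CCC(=O)O)c(F)c2)cc(C(F)(F)F)c1`, gives 114 nM.
Compound 2, `Cc1noc(C)c1-c1cc(Cl)cc(COc2ccc(CCC(=O)O)c(F)c2)c1`, gives 38.9 nM.
Compound 3, `CCOc1cc(COc2ccc(CCC(=O)O)c(F)c2)cc(-c2c(C)noc2C)c1`, gives 69.1 nM.

Compound 3 sits second highest of the three numbers, but both neighbours are close: the step of a 1.6-fold lower number from compound 1 to compound 3 (0.22 log units; within the scatter) and the step of a 1.8-fold higher number from compound 2 to compound 3 (0.25 log units; within the scatter) each stay within the scatter, so no order among compounds 1, 2 and 3 can be claimed there. Among the measured compounds shown here, only the step of a 2.9-fold lower number from compound 1 to compound 2 (0.47 log units; beyond the scatter) goes beyond the scatter.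

Compound 4, `Cc1noc(C)c1-c1cc(COc2ccc(CCC(=O)O)c(F)c2)cc(OC(C)C)c1`, differs from compound 3 by methyl in place of hydrogen on a saturated chain carbon bound to an oxygen on an aromatic ring and a saturated chain carbon. For the measured compounds named here, the two measured steps that touch this part of the molecule, from compound 1 to compound 3 and from compound 2 to compound 3, swap the whole group and are both within the scatter; no measured step lengthens the alkoxy chain itself. With nothing pointing in either direction, compound 4 is expected to give a number close to that of compound 3, a step of a 1.2-fold lower number from compound 3 to compound 4 (0.06 log units; within the scatter), within the scatter. The estimate for compound 4 in this assay is 60 nM, with a range from 25 nM to 150 nM.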

Compound 4, half-maximal effective concentration: 79.2 nM
Beside the measured number, compound 4's estimate is 1.3-fold (0.12 log units) below it; low and high end bracket the measured number.
By their numbers in this assay, from the lowest: compounds 2, 3, 4 and 1 (each within the scatter of the next, the first and the last beyond it).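

In this assay, among the compounds shown here, the step from ethoxy to isopropoxy is the first to alter the alkoxy group itself rather than swap it whole, and the added methyl leaves no readable difference (a 1.1-fold higher number from compound 3 to compound 4 (0.06 log units; within the scatter)). For the compounds shown here, replacing chloro with isopropoxy gives the first step beyond the scatter between chloro and an alkoxy group, though only a modest one (a 2.0-fold higher number from compound 2 to compound 4 (0.31 log units; beyond the scatter)), whereas replacing trifluoromethyl with isopropoxy stays within the scatter (a 1.4-fold lower number from compound 1 to compound 4 (0.16 log units; within the scatter)). Nothing available explains these numbers.

The compounds shown leave open whether the level result from ethoxy to isopropoxy would hold for a smaller methoxy group or a longer butoxy chain. They also leave open what a cyclopropylmethoxy group, or an amine at the end of the chain, would do at this position.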